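The source may hold more compounds than are shown below. What is called first, only, known or untested is meant among the compounds shown, and "the series" means these compounds.

Of the compounds shown here, three have been tested in a functional assay on MCF7 cells (Homo sapiens) for inhibition, read by sulforhodamine B assay, with a stated time of 72 h; a higher number here means a weaker inhibitor, a lower number a stronger inhibitor. Compound 1, with structure `CC(c1ccc(-c2ccccc2)c(F)c1)c1nnc2n1N=C(c1ccc(Cl)cc1Cl)CS2`, gives 7600 nM. Compound 2, with structure `CC(C)Cc1ccc(C(C)c2nnc3n2N=C(c2ccc(Cl)cc2Cl)CS3)cc1`, gives 11800 nM in this assay. Compound 3, with structure `CC(c1ccc(-c2ccccc2)c(F)c1)c1nnc2n1N=C(c1ccc(Br)cc1)CS2`, gives 7400 nM in this assay. Compound 2 shows the highest of the three numbers, but its gaps to compound 1 and to compound 3 both lie within the usual scatter of repeated measurements, so no order among the three can be read from them.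

Compound 1 and compound 3 share one core and differ in a single place: 4-bromophenyl in place of 2,4-dichlorophenyl on a carbon with a double bond to nitrogen. That change made a step of a 1.0-fold lower number from compound 1 to compound 3 (0.01 log units; within the scatter), which lies within the scatter, so it left the number essentially unchanged.

Compound 4, with structure `CC(C)Cc1ccc(C(C)c2nnc3n2N=C(c2ccc(Br)cc2)CS3)cc1`, has not yet been measured in this assay. It is related to compound 2 in exactly the same way that compound 3 is related to compound 1: 4-bromophenyl in place of 2,4-dichlorophenyl on a carbon with a double bond to nitrogen. The core of compound 2 differs from the core of compound 1, but the difference between the two cores is not broken down here.

Since the same change on the core of compound 1 produced only a 1.0-fold lower number from compound 1 to compound 3 (0.01 log units; within the scatter), the step from compound 2 to compound 4 is expected to be similarly small, around a 1.1-fold lower number from compound 2 to compound 4 (0.03 log units; within the scatter). Compound 4 is therefore estimated to give about 11000 nM in this assay, most likely between 5000 nM and 25000 nM, because compound 2 gives 11800 nM.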

Compound 4, half-maximal inhibitory concentration: 9400 nM
The estimate for compound 4 lay 1.2-fold (0.07 log units) above the measured number, and the stated range covers the measured number.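

Putting 4-bromophenyl in place of 2,4-dichlorophenyl on the core of compound 2 gives a 1.3-fold lower number from compound 2 to compound 4 (0.10 log units; within the scatter) in this assay, so compound 2 and compound 4 cannot be told apart by this measurement. Set beside the earlier case, the change behaves alike on both cores, with neither step large enough to read as a real shift and no readable difference between the two steps: the same change on two cores in this assay, a 1.0-fold lower number (0.01 log units; within the scatter) from compound 1 to compound 3 and a 1.3-fold lower number (0.10 log units; within the scatter) from compound 2 to compound 4, 1.2-fold (0.09 log units) apart, within the scatter of two such steps. This shows only that, on these two cores, the swap leaves the number within the noise of the measurement; it does not show that the same would hold on a third core, and it cannot say whether the two groups would differ on a core where the swap has a readable effect.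

The phenyl ring at this place carries only chlorine or bromine in the compounds shown, so it stays open whether an amine, a carboxylic acid or a longer chain on that ring would move the number beyond the scatter. Also open, from the compounds shown here alone, is what a phenyl ring with no halogen at all would give on either core, which would show whether the halogens matter here at all.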